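A few compounds are considered here, and "the series" means these few. Any claim that something is new, unique, unknown or untested is made for them only; others in the source may bear on it.

Within the data shown here, compound 2 `O=C(CSc1snnc1-c1ccc(Br)cc1Br)Nc1cccnc1Cl` is one of two compounds measured in an ADME assay on MT4 cells (Homo sapiens) for cytotoxicity, read by MTT assay, with a stated time of 5 days; a lower number here means that less compound is tolerated, a higher number that more compound is tolerated. In this assay compound 2 gives > 240000 nM, which is a limit of the assay and not a number. The other, compound 1 `O=C(CSc1snnc1-c1ccc(Br)cc1Br)Nc1ccccn1`, gives 42400 nM in this assay, and the step of an at least 5.6-fold higher number from compound 1 to compound 2 (0.75 log units; beyond the scatter) is the only measured one, with compound 2 sitting at the limit of > 240000 nM in this assay, at which 1 of the 2 values shown sits. Compound 3 `Cc1ccc(NC(=O)CSc2snnc2-c2ccc(Br)cc2Br)cc1` differs from compound 2 by 4-methylphenyl in place of 2-chloropyridin-3-yl on an amide-type nitrogen. Among the measured compounds shown here, no measured step covers a change of this kind, so the expectation rests only loosely on that one step, and compound 3 is estimated at 100000 nM (range 30000 nM to 300000 nM), an expected step of an at least 2.4-fold lower number from compound 2 to compound 3 (0.38 log units; beyond the scatter).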

Compound 3, half-maximal cytotoxic concentration: 24000 nM
Compound 3: middle estimate off by 4.2-fold (0.62 log units), on the high side, and the stated range ends above it.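

In this assay, 4-methylphenyl on the amide-type nitrogen gives an at least 10-fold lower number from compound 2 to compound 3 (1.00 log units; beyond the scatter) while the other comparison gives a 1.8-fold lower number from compound 1 to compound 3 (0.25 log units; within the scatter) and so stays within the scatter. Among these three compounds, only the 2-chloropyridin-3-yl group of compound 2 stands apart, and compound 1 and compound 3 show no separation. The first step has only a lower bound, since the value of compound 2 is a limit of the assay and not a number: the limit of > 240000 nM in this assay, at which 1 of the 3 values shown sits.

From the compounds shown here alone, whether the chlorine or the ring nitrogen of 2-chloropyridin-3-yl carries the step stays open. So does the outcome with an amine or a carboxylic acid on that ring.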